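A few compounds are considered here, and "the series" means these few. Any claim that something is new, unique, unknown or untested is made for them only; others in the source may bear on it.

Measured compounds:
compound 1 `CCN(CC)CCCOc1ccc2cc(NC(=O)c3ccc(O)c(CC=C(C)C)c3)c(=O)oc2c1C` — 4900 nM
compound 2 `CC(C)=CCc1cc(C(=O)Nc2cc3ccc(OCCCN(C(C)C)C(C)C)c(C)c3oc2=O)ccc1O` — 1600 nM
compound 3 `CC(C)=CCc1cc(C(=O)Nc2cc3ccc(OCCCNC4CCCCC4)c(C)c3oc2=O)ccc1O` — 660 nM

All three were tested in a functional assay on SK-BR-3 cells (Homo sapiens) for antiproliferative activity (on this read-out lower numbers stand for stronger inhibition and higher numbers for weaker inhibition), where compound 1 gives 4900 nM, the highest of the three numbers and so the weakest inhibition seen here. Compound 2 gives 1600 nM and compound 3 gives 660 nM.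

Compound 4 `CC(C)=CCc1cc(C(=O)Nc2cc3ccc(OCCCN(C)C4CCCCC4)c(C)c3oc2=O)ccc1O` has not yet been tested. Relative to compound 1 it carries cyclohexyl(methyl)amino in place of diethylamino on a saturated chain carbon, three bonds along the chain from an oxygen on an aromatic ring.

Within the data shown here, two measured steps bear on this change. Both alter the same amine on the same chain: a 3.1-fold lower number from compound 1 to compound 2 (0.49 log units; beyond the scatter) and a 7.4-fold lower number from compound 1 to compound 3 (0.87 log units; beyond the scatter). Compound 3 stands apart from compound 2 as well, a 2.4-fold lower number from compound 2 to compound 3 (0.38 log units; beyond the scatter). Every change away from diethylamino at this place has so far lowered the number beyond the scatter, and the cyclohexyl-bearing compound 3 gives the lowest number. Compound 4 joins a cyclohexyl ring to an amine without a hydrogen-bond donor, as in compound 2, so a modest improvement is expected for compound 4, a 5.4-fold lower number from compound 1 to compound 4 (0.74 log units; beyond the scatter), likely landing between compound 2 and compound 3. The estimated value for compound 4 in this assay is 900 nM, with a range from 350 nM to 2500 nM.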

Compound 4, half-maximal inhibitory concentration: 970 nM
Compound 4: middle estimate off by 1.1-fold (0.03 log units), on the low side; low and high end bracket the measured number.
By their numbers in this assay, from the lowest: compounds 3, 4 and 2 (each within the scatter of the next, the first and the last beyond it); then compound 1.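

In this assay, cyclohexyl(methyl)amino in place of diethylamino gives a 5.1-fold lower number from compound 1 to compound 4 (0.70 log units; beyond the scatter), so a third amine at this place now stands apart from diethylamino, and this one has a ring but no hydrogen on the nitrogen, just like diethylamino. Methyl in place of hydrogen on the amine nitrogen gives a 1.5-fold higher number from compound 3 to compound 4 (0.17 log units; within the scatter) and the swap from diisopropylamino gives a 1.6-fold lower number from compound 2 to compound 4 (0.22 log units; within the scatter), so compound 4 cannot be told apart from either neighbour, even though compound 2 and compound 3 do differ from each other, and the amine hydrogen of compound 3 is not shown to matter in these cells. No measurement at hand accounts for any of these differences.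

On these data alone, it remains open how an amine whose nitrogen sits inside the ring, such as piperidine or morpholine, would compare with these open-chain and cyclohexyl amines. Also open, as far as these compounds go, is whether the cyclohexyl(methyl)amino group would give a similar number on a 2-(cyclohexyl(methyl)amino)ethyl chain or on a longer chain than the 3-(cyclohexyl(methyl)amino)propyl chain of compound 4.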